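The source may hold more compounds than are shown below. What is called first, only, known or untested is meant among the compounds shown, and "the series" means these compounds.

Working notes on the series in an assay for inhibition of Tryptophan 2,3-dioxygenase (Homo sapiens), with stated times of 10 min and 60 min, tested at 100 uM; on this read-out higher numbers stand for a stronger effect at the one concentration tested and lower numbers for a weaker effect.

Of the compounds shown here, three have numbers so far. Compound 1 `O=[N+]([O-])c1cccc(CNc2cc(C(F)(F)F)cc3[nH]ncc23)c1` gives 82% in this assay. Compound 3 `FC(F)(F)c1cccc(CNc2cc(C(F)(F)F)cc3[nH]ncc23)c1` gives 74%. Compound 2 `FC(F)(F)c1cc(NCc2cccc3sccc23)c2cn[nH]c2c1`, built on a different core, gives 5%. Compound 3 thus stands second highest of the three numbers, with compound 1 nearest and compound 2 furthest; the gap to compound 2 is beyond the scatter, the gap to compound 1 is not.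

One step between measured compounds is available: a number 8 percentage points lower from compound 1 to compound 3 (within the scatter). It shows that exchanging the substituent on the pendant aromatic ring between nitro and trifluoromethyl leaves the read-out where it was, within the scatter.

Compound 4 `OC1CCCC(Nc2cccc(CNc3cc(C(F)(F)F)cc4[nH]ncc34)c2)C1` is not yet measured. It differs from compound 3 in one place: (3-hydroxycyclohexyl)amino in place of trifluoromethyl on an aromatic carbon. Within the data shown here, no measured step covers a change of this kind; the only step in hand swaps one small group for another at the same place and stays within the scatter. The entering group is far larger and carries donors and acceptors that neither earlier substituent had, so the scatter-sized outcome of the step from compound 1 to compound 3 cannot simply be carried over. The estimate is therefore wide.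

For compound 4 the expected read-out is 60%, within 25% to 90%, which means an expected step of a number 14 percentage points lower from compound 3 to compound 4 (beyond the scatter).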

Compound 4, a percentage reported as inhibition, at one concentration (the size of the read-out at that concentration, not a potency): 23%
The estimate for compound 4 lay 37 percentage points above the measured number, and the stated range ends above it.
By their numbers in this assay, from the lowest: compound 2; then compound 4; then compounds 3 and 1 (each within the scatter of the next).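

In this assay the aromatic carbon that took either nitro or trifluoromethyl with no difference beyond the scatter does not tolerate every group, since (3-hydroxycyclohexyl)amino gives a number 51 percentage points lower from compound 3 to compound 4 (beyond the scatter) and a number 59 percentage points lower from compound 1 to compound 4 (beyond the scatter) with that group in place. Both steps are large, so the drop appears whichever of the two earlier substituents serves as the reference. No measurement in hand speaks to why the number fell.

The change brings in a non-aromatic ring, a nitrogen and a hydroxyl together, and the compounds shown cannot tell which of these goes with the drop. A plain cyclohexylamino group, a bare amine, a methoxy group or a carboxylic acid on the same aromatic carbon would help to separate these parts and to show how large a group this position accepts before the read-out falls away from that of compound 3 and compound 1.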